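The compounds below may be only part of what the source reports. "The series", "measured", "known", "first", "only" and "open" are said of these compounds alone.

Measured in an assay on lung parenchyma for binding affinity to cysteinyl leukotriene receptor 1 (Cavia porcellus), read by radioligand binding; a lower number here means a stronger inhibitor, a higher number a weaker inhibitor:
- compound 1 `COc1cc(C(=O)NS(=O)(=O)c2ccccc2C)ccc1Cc1cn(C)c2ccc(C(=O)NCC3CCCC3)cc12`: 3.16 nM
- compound 2 `CCC(C)CNC(=O)c1ccc2c(c1)c(Cc1ccc(C(=O)NS(=O)(=O)c3ccccc3C)cc1OC)cn2C`: 5.01 nM
- compound 3 `CCC(CC)CNC(=O)c1ccc2c(c1)c(Cc1ccc(C(=O)NS(=O)(=O)c3ccccc3C)cc1OC)cn2CC`: 1 nM

Compound 3 gives the lowest number of the three in this assay; the gaps to compound 1 and to compound 2 both lie beyond the scatter, so compound 3 is the strongest binder of the measured set.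

Compound 4 `CCCn1cc(Cc2ccc(C(=O)NS(=O)(=O)c3ccccc3C)cc2OC)c2cc(C(=O)NCC(CC)CC)ccc21` differs from compound 3 by methyl in place of hydrogen on a saturated chain carbon, two bonds along the chain from an aromatic nitrogen; read one bond further out, the ethyl on the aromatic nitrogen becomes propyl. Among the compounds with values here, no measured step touches this part of the molecule. Within the data shown here, the only single-point step, a 1.6-fold higher number from compound 1 to compound 2 (0.20 log units; within the scatter), concerns the amide side chain and lies within the scatter. Compound 3 differs from compound 1 and compound 2 in two places at once, so its lower number cannot be assigned to the ethyl alone. Homologation by one carbon at this position is therefore expected to give no step beyond the scatter, with a slight lean toward a lower number: the expected step is a 1.1-fold lower number from compound 3 to compound 4 (0.05 log units; within the scatter). Compound 4 is estimated at 0.9 nM, range 0.4 nM to 2.5 nM.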

Compound 4, inhibition constant: 0.794 nM
Compound 4: the middle estimate sits 1.1-fold (0.05 log units) above what was measured; the range from low to high includes it.
By their numbers in this assay, from the lowest: compounds 4 and 3 (each within the scatter of the next); then compounds 1 and 2 (each within the scatter of the next).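

In this assay, the change of ethyl to propyl on the aromatic nitrogen gives a 1.3-fold lower number from compound 3 to compound 4 (0.10 log units; within the scatter), so methyl in place of hydrogen on this saturated chain carbon causes no step beyond the scatter. Within the data shown here, the earlier compounds varied the group on the aromatic nitrogen only together with the amide side chain, so this is the one reading of this position on its own, made with the amide side chain held fixed. No measurement here bears on why the change leaves the number within the scatter.

On these data alone, whether a butyl chain, a branched isopropyl group or a carboxylic acid at the end of the chain would also stay within the scatter remains open. Also open, as far as these compounds go, is the effect of methyl to ethyl on the aromatic nitrogen with the amide side chain held fixed.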